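Changing the Ring Amine Substituent to an Amide

The source may report more compounds than this note shows. Statements on the series, on what has been measured and on what is new or still open speak of the compounds shown alone.

Compound 1 `Fc1cccc(C#Cc2nc3c(s2)CN(C2CCC2)CC3)c1` carries a cyclobutyl group on an amine nitrogen in a ring of the shared core. In an assay on HEK293 cells for positive allosteric modulation of metabotropic glutamate receptor 5 (Homo sapiens), read by FLIPR, with a stated time of 1 h (on this read-out lower numbers stand for an effect already at smaller amounts and higher numbers for an effect only at larger amounts of compound), compound 1 reaches only the limit > 10000 nM and gives no number. Compound 2 `Fc1cccc(C#Cc2nc3c(s2)CN(C2CCOC2)CC3)c1` carries oxolan-3-yl on the same amine nitrogen in a ring. In this assay compound 2 likewise yields only the limit > 10000 nM. The step that the two limits leave unreadable from compound 1 to compound 2 is accordingly unreadable, since both values sit at the limit of > 10000 nM in this assay, at which 2 of the 2 values shown sit. Compound 3 `O=C(C1CC(F)(F)C1)N1CCc2nc(C#Cc3cccc(F)c3)sc2C1` differs from compound 2 by (3,3-difluorocyclobutyl)carbonyl in place of oxolan-3-yl on an amine nitrogen in a ring. Going by the values given here, no measured step bears on this change: the one step recorded is unreadable and both values are limits. For compound 3 the present writer therefore expects only a broad estimate of 2000 nM, ranging from 100 nM to 15000 nM. The expected step of an at least 5.0-fold lower number from compound 2 to compound 3 (0.69 log units; beyond the scatter) is thus itself uncertain and may remain unreadable.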

Compound 3, half-maximal effective concentration: 2.5 nM
The estimate for compound 3 lay 800-fold (2.90 log units) above the measured number; the measured number lies below the stated range.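

In this assay the substituent on the amine nitrogen in a ring proves decisive, as (3,3-difluorocyclobutyl)carbonyl gives an at least 4000-fold lower number from compound 2 to compound 3 (3.60 log units; beyond the scatter) and, against the cyclobutyl group, an at least 4000-fold lower number from compound 1 to compound 3 (3.60 log units; beyond the scatter) in the same comparison. Both steps start from a limit, so they give only a minimum size. Compound 3 is the only compound shown that yields a number, whereas the two amines with cyclobutyl and oxolan-3-yl stay at the limit: the limit of > 10000 nM in this assay, at which 2 of the 3 values shown sit.

The compounds shown do not separate the carbonyl from the two fluorine atoms of the entering group, and a plain cyclobutylcarbonyl group on the same nitrogen would tell these apart. They also leave open whether a different amide, such as acetyl, or a urea at this nitrogen would give a similar number.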